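Swapping a halogenated ring in a chalcone-like series

The source may report more compounds than this note shows. Statements on the series, on what has been measured and on what is new or still open speak of the compounds shown alone.

Three compounds have numbers in a functional assay on MGC-803 cells (Homo sapiens) for antiproliferative activity, read by MTT assay, with a stated time of 72 h; a higher number here means a weaker inhibitor, a lower number a stronger inhibitor. Among the measured compounds shown here, compound 1, with structure `O=C(COc1ccc(C(=O)/C=C/c2cccc(Cl)c2)cc1)N[C@H]1CCOC1=O`, gives 29100 nM in this assay, and this is the only outright number among the three. Compound 2, with structure `O=C1OCC[C@@H]1NC(=S)SCCOc1ccc([N+](=O)[O-])cc1`, reaches only a limit of the assay in this assay, reported as > 100000 nM. Compound 3, with structure `O=C(CNc1ccccc1)N[C@H]1CCOC1=O`, likewise stops at a limit in this assay, reported as > 64000 nM. For the measured compounds named here, compound 1 therefore stands alone as the one measured value, with no measured step to compare it against.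

Compound 4, with structure `O=C(COc1ccc(C(=O)/C=C/c2ccccc2Br)cc1)N[C@H]1CCOC1=O`, differs from compound 1 in one place: 2-bromophenyl in place of 3-chlorophenyl on a double-bonded chain carbon bound to a double-bonded chain carbon. Going by the values given here, no step between two measured compounds exists here to show how such a change moves the number, so the expectation rests on compound 1 alone and on the modest nature of the swap. The step from compound 1 to compound 4 is expected to stay within the usual scatter, a 1.1-fold higher number from compound 1 to compound 4 (0.04 log units; within the scatter). Compound 4 is accordingly estimated at 32000 nM in this assay, within a range from 10000 nM to 95000 nM.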

Compound 4, half-maximal inhibitory concentration: 12200 nM
The estimate for compound 4 lay 2.6-fold (0.42 log units) above the measured number, within the range that was stated.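

In this assay, among the compounds shown here, this is the first measured step in the set, and going to 2-bromophenyl gives a 2.4-fold lower number from compound 1 to compound 4 (0.38 log units; beyond the scatter), a modest move but one beyond the scatter. The group on a double-bonded chain carbon bound to a double-bonded chain carbon is therefore a place where the number responds, even to a swap that leaves the heavy-atom count unchanged. The swap alters both the halogen and its numbered place on the ring, and nothing measured here shows which of the two accounts for the step, or why the number moves at all.

As far as these compounds go, a 2-chlorophenyl or 3-bromophenyl group would separate those two changes, and their values remain open. Also open, from the compounds shown here alone, is how the number would respond to an amine or a carboxylic acid on this ring in place of the halogen.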